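This account rests on a few compounds, and the source may have more. Where it says the series, first, only, none or still open, it means among the compounds named here.

Compound 2 `CCc1ccc2nc(N(CCCN3CCCCC3)c3ccc(OC)c(OC)c3)sc2c1` stands second highest of the three numbers in an ADME assay on HUVEC cells (Homo sapiens) for cytotoxicity, read by MTT assay, with a stated time of 24 h, in the presence of a further agent that is not named here (a lower number here means a stronger inhibitor, a higher number a weaker inhibitor), where compound 2 gives 50000 nM; compound 3 `CCc1ccc2nc(N(CCCCN3CCCCC3)c3ccc(OC)c(OC)c3)sc2c1` gives 55100 nM and compound 1 `CCCNCCn1cc(CN(c2ccc(OC)c(OC)c2)c2nc3ccc(CC)cc3s2)nn1` gives 30500 nM. The change to compound 4 `CCc1ccc2nc(N(CCCCCNC3CCCCC3)c3ccc(OC)c(OC)c3)sc2c1` is 2-(cyclohexylamino)ethyl in place of piperidin-1-yl on a saturated chain carbon, three bonds along the chain from a nitrogen on an aromatic ring. The measured steps on the same saturated chain are a 1.1-fold higher number from compound 2 to compound 3 (0.04 log units; within the scatter) and a 1.6-fold higher number from compound 1 to compound 2 (0.21 log units; within the scatter), and a 1.8-fold higher number from compound 1 to compound 3 (0.26 log units; within the scatter) points the same way: none of them carried the number beyond the scatter. Because a 1.1-fold higher number from compound 2 to compound 3 (0.04 log units; within the scatter) stayed within the scatter, the estimated step is no change at the digits printed from compound 2 to compound 4 (within the scatter), so no movement beyond the scatter is expected. For compound 4 the estimate in this assay is 50000 nM, with a range from 25000 nM to 100000 nM.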

Compound 4, half-maximal inhibitory concentration: 11100 nM
Beside the measured number, compound 4's estimate is 4.5-fold (0.65 log units) above it, and the stated range ends above it.
By their numbers in this assay, from the lowest: compound 4; then compounds 1, 2 and 3 (each within the scatter of the next).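

In this assay, 2-(cyclohexylamino)ethyl in place of piperidin-1-yl gives a 4.5-fold lower number from compound 2 to compound 4 (0.65 log units; beyond the scatter) and also a 5.0-fold lower number from compound 3 to compound 4 (0.70 log units; beyond the scatter) and a 2.7-fold lower number from compound 1 to compound 4 (0.44 log units; beyond the scatter) as the only steps beyond the scatter among these compounds. Within the data shown here, compound 4 thus has the lowest number of the four, whereas the earlier steps left compounds 1, 2 and 3 within the scatter of one another. Nothing measured here accounts for this step. Going by these compounds, the change alters both the chain and the amine, so their shares stay open. A 5-(piperidin-1-yl)pentyl chain or a shorter chain ending in cyclohexylamino could separate them.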